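The source may hold more compounds than are shown below. What is called first, only, known or untested is meant among the compounds shown, and "the series" means these compounds.

Three members of the series have numbers in a functional assay on MCF7 cells (Homo sapiens) for antiproliferative activity; a lower number here means a stronger inhibitor, a higher number a weaker inhibitor. Compound 1 `C#CCCn1c(Cc2cc(OC)c(OC)c(OC)c2)nc2c(N)nc(F)nc21` gives 25100 nM and compound 3 `CCCn1c(Cc2cc(OC)c(OC)c(OC)c2)nc2c(N)nc(F)nc21` gives 25100 nM. Compound 2 `COc1cc(Cc2nc3c(N)ncnc3n2CC(C)C)cc(OC)c1OC` gives 97700 nM, the highest of the three and beyond the scatter from both compound 1 and compound 3, so it is the weakest inhibitor measured. Compound 4 `COCCn1c(Cc2cc(OC)c(OC)c(OC)c2)nc2c(N)ncnc21` differs from compound 2 by methoxymethyl in place of isopropyl on a saturated chain carbon bound to an aromatic nitrogen. For the measured compounds named here, the one single-point step available, no change at the digits printed from compound 1 to compound 3 (within the scatter), sits two bonds along the chain from the aromatic nitrogen and bears only loosely on a change at the chain carbon bound to that nitrogen; no measured step exchanges a carbon-only group for one carrying a hydrogen-bond acceptor on this chain. For compound 4 the expected step is therefore a 1.4-fold lower number from compound 2 to compound 4 (0.14 log units; within the scatter), probably within the scatter. Compound 4 is estimated at 70000 nM, range 20000 nM to 250000 nM.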

Compound 4, half-maximal inhibitory concentration: 64600 nM
For compound 4 the middle estimate is 1.1-fold (0.03 log units) above the measured one, within the range that was stated.
By their numbers in this assay, from the lowest: compounds 1 and 3 (each within the scatter of the next); then compounds 4 and 2 (each within the scatter of the next).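

Methoxymethyl in place of isopropyl on a saturated chain carbon bound to an aromatic nitrogen gives a 1.5-fold lower number from compound 2 to compound 4 (0.18 log units; within the scatter) in this assay and so stays within the scatter. For the compounds shown here, this is the first measured exchange on this chain of a carbon-only group for one carrying a hydrogen-bond acceptor, and here the acceptor brings no separable difference. No supporting measurement bears on this result.

The compounds shown leave open whether an amine, a carboxylic acid or a longer chain at this place would move the number beyond the scatter. Going by these compounds, whether the same exchange reads alike on the core of compound 1 also remains open.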